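The source may report more compounds than this note shows. Statements on the series, on what has been measured and on what is new or still open speak of the compounds shown alone.

Working notes on the series. Compound 1 `O=c1cc(CCCl)c2ccc(OCc3cccc(Cl)c3)cc2o1` gives 12.9 nM in an assay on brain (strain Sprague-Dawley) for inhibition of Amine oxidase [flavin-containing] B (Rattus norvegicus), read by spectrophotometry; on this read-out higher numbers stand for weaker inhibition and lower numbers for stronger inhibition. Compound 2 `O=c1cc(CCBr)c2ccc(OCc3cccc(Cl)c3)cc2o1` gives 32.4 nM in this assay, which is the highest of the two numbers measured; the step of a 2.5-fold higher number from compound 1 to compound 2 (0.40 log units; beyond the scatter) separates it from compound 1, its nearest neighbour. Compound 3 `O=C(O)CCc1cc(=O)oc2cc(OCc3cccc(Cl)c3)ccc12` remains unmeasured in this assay. Relative to compound 2, the change is carboxy in place of bromo on a saturated chain carbon, two bonds along the chain from an aromatic carbon. Within the data shown here, the only measured step is a 2.5-fold higher number from compound 1 to compound 2 (0.40 log units; beyond the scatter), an exchange at the same chain carbon, and it does not involve a carboxy group, so it bears on the present change only in showing that this carbon is sensitive to what sits on it. Compound 3 is therefore expected to read weaker than compound 2, by the step of a 4.6-fold higher number from compound 2 to compound 3 (0.67 log units; beyond the scatter), with wide uncertainty. The estimate for compound 3 in this assay is 150 nM, expected between 25 nM and 1000 nM.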

Compound 3, half-maximal inhibitory concentration: 1200 nM
Compound 3: the middle estimate sits 8.0-fold (0.90 log units) below what was measured; the whole stated range lies below it.
By their numbers in this assay, from the lowest: compound 1; then compound 2; then compound 3.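

At this saturated chain carbon, two bonds along the chain from an aromatic carbon, carboxy reads far weaker than either halogen in this assay: carboxy in place of bromo gives a 37-fold higher number from compound 2 to compound 3 (1.57 log units; beyond the scatter), and carboxy in place of chloro gives a 93-fold higher number from compound 1 to compound 3 (1.97 log units; beyond the scatter). Both steps are large, whereas the exchange between chloro and bromo was modest, so this position separates groups far more widely than the two halogens alone showed. No supporting data bear on this loss, and no cause can be assigned to it.

The compounds shown leave open whether the loss belongs to the carboxy group itself or would also appear with a methyl ester, a primary amide or an amine on the same carbon. They also leave open whether a longer chain carrying the carboxylic acid would read differently from the 2-carboxyethyl group.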